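The source may report more compounds than this note shows. Statements on the series, on what has been measured and on what is new or still open speak of the compounds shown alone.

Compound 1 `CC(C)[S+]([O-])CCCCN=C=S` is the anchor of this series. In a functional assay on HepG2 cells (Homo sapiens) for cytotoxicity, read by MTT assay, with a stated time of 72 h (a higher number here means a weaker inhibitor, a lower number a stronger inhibitor), compound 1 gives 2050 nM. Compound 2 `[O-][S+](CCCCN=C=S)Cc1ccccc1` shares its chain but carries a different group on the sulfur; the difference between the two cores is not broken down here. In this assay compound 2 gives 2850 nM, and compound 3 `[O-][S+](CCCCCN=C=S)Cc1ccccc1` gives 3910 nM. From compound 2 to compound 3 the change is a group of 4 heavy atoms (2 carbon, 1 nitrogen, 1 sulfur; no ring) in place of a group of 3 heavy atoms (1 carbon, 1 nitrogen, 1 sulfur; no ring), on a saturated chain carbon, four bonds along the chain from a sulfur, and it produced a 1.4-fold higher number from compound 2 to compound 3 (0.14 log units; within the scatter). Compound 4 `CC(C)[S+]([O-])CCCCCN=C=S` carries the same change made on compound 1, namely (a group of 4 heavy atoms (2 carbon, 1 nitrogen, 1 sulfur; no ring) in place of a group of 3 heavy atoms (1 carbon, 1 nitrogen, 1 sulfur; no ring), on a saturated chain carbon, four bonds along the chain from a sulfur); the change appears twice among these compounds. Because a 1.4-fold higher number from compound 2 to compound 3 (0.14 log units; within the scatter) was small, compound 4 is expected to show a similar step, a 1.4-fold higher number from compound 1 to compound 4 (0.14 log units; within the scatter). The estimate for compound 4 in this assay is therefore 2800 nM, expected to fall between 1500 nM and 5200 nM.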

Compound 4, half-maximal inhibitory concentration: 3690 nM
Beside the measured number, compound 4's estimate is 1.3-fold (0.12 log units) below it, and the stated range covers the measured number.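

In this assay the new step is a 1.8-fold higher number from compound 1 to compound 4 (0.26 log units; within the scatter), so on the core of compound 1 the change again stays within the scatter. Set beside the earlier step, the two cores show no difference in how they take this change: the same change on two cores in this assay, a 1.4-fold higher number (0.14 log units; within the scatter) from compound 2 to compound 3 and a 1.8-fold higher number (0.26 log units; within the scatter) from compound 1 to compound 4, 1.3-fold (0.12 log units) apart, within the scatter of two such steps. This shows that, on these two cores, the change gave steps that cannot be told apart, but it does not show that the change has a real effect on either core, and two pairs give no rule for other cores.

As far as these compounds go, whether a longer chain or an amine would give a step beyond the scatter stays open. From the compounds shown here alone, how a core other than these two would respond also stays open.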